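The source may report more compounds than this note shows. Statements on the series, on what has been measured and on what is new or still open speak of the compounds shown alone.

Working notes on the series in an ADME assay on microsomes from liver (Mus musculus) for metabolic stability, read by HPLC, using NADPH, with a stated time of 60 min, tested at 1 uM, in the presence of a further agent that is not named here; a higher number here means faster removal of the compound, a lower number slower removal. Compound 1 `O=C(NNS(=O)(=O)c1ccccc1F)c1cc(F)cc(-n2cccn2)c1` gives 334 uL/min, and compound 2 `Cc1cc(-c2ccccn2)cc(C(=O)NNS(=O)(=O)c2ccccc2)c1F` gives 424 uL/min; the two numbers sit within the usual scatter of each other, so no order can be set between compound 1 and compound 2, and both are removed quickly in this preparation. Compound 3 `C=CCOc1cc(F)cc(C(=O)NNS(=O)(=O)c2ccccc2F)c1` has not yet been run in this assay. Against compound 1 it shows (allyloxy in place of 1H-pyrazol-1-yl on an aromatic carbon). For the measured compounds named here, no measured pair in the set carries this change, so there is no measured step to lean on; the only guide is that compound 1 and compound 2, which also differ on the core, fall close together. On that basis the step expected from compound 1 to compound 3 is a 1.1-fold higher number from compound 1 to compound 3 (0.06 log units; within the scatter), a change not expected to go beyond the scatter in either direction. Compound 3 is estimated at 380 uL/min, with a range from 190 uL/min to 760 uL/min.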

Compound 3, intrinsic clearance in a liver preparation (reported as CLH), per the amount of preparation that the assay uses: 803 uL/min
For compound 3 the middle estimate is 2.1-fold (0.32 log units) below the measured one, and the stated range ends below it.
By their numbers in this assay, from the lowest: compounds 1, 2 and 3 (each within the scatter of the next, the first and the last beyond it).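

In this assay this position on the shared core responds to the group it carries: allyloxy in place of 1H-pyrazol-1-yl gives a 2.4-fold higher number from compound 1 to compound 3 (0.38 log units; beyond the scatter), a modest step and the first in the series that can be read on a single change. On this one pair, an open chain with a double bond outside aromatic rings, standing where a five-membered aromatic ring stood, goes with faster removal. Nothing at hand bears on the reason for this step, so it stands as an observation only.

On these data alone, whether the step follows the loss of the ring or the arrival of the double bond stays open; a propoxy group at this position would separate the two. Also open, as far as these compounds go, is whether another ring here, such as phenyl or 1H-imidazol-1-yl, would fall nearer compound 1 or compound 3.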